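Dimethoxy in place of dichloro on the benzylamine arm

The compounds below may be only part of what the source reports. "The series", "measured", "known", "first", "only" and "open" are said of these compounds alone.

Compound 1 `Nc1cc(N)c2nc(-c3ccccc3)c(Oc3ccc(Cl)c(Cl)c3)nc2c1`, compound 2 `CCOC(=O)[C@H](CCC(=O)O)NC(=O)c1ccc(CNc2nc3cc(N)cc(N)c3nc2-c2ccccc2)cc1` and compound 3 `Nc1cc(N)c2nc(-c3ccccc3)c(NCc3ccc(Cl)c(Cl)c3)nc2c1` share one core bearing two amino groups and a phenyl group. Going by the values given here, in a functional assay on 786-0 cells (Homo sapiens) for inhibition, read by sulforhodamine B assay, with a stated time of 48 h (a lower number here means a stronger inhibitor of growth, a higher number a weaker inhibitor of growth), compound 3 gives 30200 nM, the lower of the two numbers known, while compound 1 gives 44700 nM, a gap within the scatter. Compound 2 gives < 100000 nM, which is a limit of the assay and not a number, namely (the limit of < 100000 nM in this assay, at which 1 of the 3 values shown sits). Compound 4 `COc1ccc(CNc2nc3cc(N)cc(N)c3nc2-c2ccccc2)cc1OC` differs from compound 3 by 3,4-dimethoxyphenyl in place of 3,4-dichlorophenyl on a saturated chain carbon bound to a nitrogen on an aromatic ring. Among the compounds with values here, no step between measured compounds is known, so in this assay the expected change is none beyond the scatter, with weaker inhibition of growth the more likely direction. Compound 4 is expected at 40000 nM, with a range from 12000 nM to 100000 nM. That estimate means an expected step of a 1.3-fold higher number from compound 3 to compound 4 (0.12 log units; within the scatter).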

Compound 4, concentration for total growth inhibition: 34700 nM
Estimate against measurement, compound 4: 1.2-fold (0.06 log units) above; measured number inside the range.
By their numbers in this assay, from the lowest: compounds 3, 4 and 1 (each within the scatter of the next).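

In this assay, 3,4-dimethoxyphenyl in place of 3,4-dichlorophenyl on a saturated chain carbon bound to a nitrogen on an aromatic ring gives a 1.1-fold higher number from compound 3 to compound 4 (0.06 log units; within the scatter). This first readable step at this position shows that exchanging chlorine for methoxy groups, which brings in hydrogen-bond acceptors, leaves growth inhibition unchanged within the scatter. No measurement shown here offers a cause for this result. As far as these compounds go, whether a nitrile or a trifluoromethyl group on this phenyl ring would give a step beyond the scatter remains open.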